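This account rests on a few compounds, and the source may have more. Where it says the series, first, only, none or still open, it means among the compounds named here.

Series notes. In an ADME assay for permeability, using PAMPA, with a stated time of 30 min, at pH 7.4 (a lower number here means that the compound crosses the layer more slowly, a higher number that the compound crosses the layer faster), compound 2 `Fc1ccc(-c2ccc3c(NCCCNCc4ccco4)ccnc3c2)cc1` gives 237 10^-6 cm/s and compound 3 `COc1cccc(CNCCCNc2ccnc3cc(-c4ccc(F)cc4)ccc23)c1O` gives 237 10^-6 cm/s, level with each other at the digits printed and together the highest of the three numbers, while compound 1 `COc1ccc(F)cc1CNCCCNc1ccnc2cc(C3CCCCC3)ccc12` gives 23 10^-6 cm/s, the furthest from compound 2. Going by the values given here, the single step measured so far, no change at the digits printed from compound 2 to compound 3 (within the scatter), alters only the group on the chain side of the shared core. Compound 4 `COc1cccc(Oc2ccc3c(NCCCNCc4ccco4)ccnc3c2)c1` instead carries 3-methoxyphenoxy in place of 4-fluorophenyl on an aromatic carbon. Among the compounds with values here, no measured step touches that position, so the move to compound 4 can only be weighed against the spread already seen. In this assay compound 4 is therefore expected near 200 10^-6 cm/s, within 80 10^-6 cm/s to 400 10^-6 cm/s. The step of a 1.2-fold lower number from compound 2 to compound 4 (0.07 log units; within the scatter) is expected to stay within the scatter.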

Compound 4, apparent permeability: 317 10^-6 cm/s
Beside the measured number, compound 4's estimate is 1.6-fold (0.20 log units) below it; measured number inside the range.
By their numbers in this assay, from the lowest: compound 1; then compounds 2, 3 and 4 (each within the scatter of the next).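

The aromatic carbon of the shared core now has its first measured step, and in this assay the exchange stays within the scatter (a 1.3-fold higher number from compound 2 to compound 4 (0.13 log units; within the scatter)). At this position, 3-methoxyphenoxy, which has hydrogen-bond acceptors where 4-fluorophenyl has none, therefore gives a read-out indistinguishable from that of 4-fluorophenyl. No measurement available here accounts for this result.

As far as these compounds go, whether an amine or a carboxylic acid at this aromatic carbon would keep the read-out in the same range remains open. Also open, from the compounds shown here alone, is whether 3-methoxyphenoxy would behave alike with the 2-hydroxy-3-methoxyphenyl group of compound 3 on the chain.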